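Methyl ester in place of acid on a triazole series

A few compounds are considered here, and "the series" means these few. Any claim that something is new, unique, unknown or untested is made for them only; others in the source may bear on it.

Four compounds share a core in which a phenol ring carrying an acid or ester is joined through a triazole to a second, substituted phenyl ring. Compound 2 `COc1cc(OC)cc(-c2cn(-c3ccc(O)c(C(=O)O)c3)nn2)c1` carries a free acid and two methoxy groups on the outer ring, compound 1 `COC(=O)c1cc(-n2cc(-c3cc(OC)cc(OC)c3)nn2)ccc1O` is its methyl ester, compound 3 `COc1ccccc1-c1cn(-c2ccc(O)c(C(=O)O)c2)nn1` carries the free acid with a single methoxy group on the outer ring, and compound 4 `COC(=O)c1cc(-n2cc(-c3ccccc3OC)nn2)ccc1O` is the methyl ester of compound 3.

In a functional assay on CCRF-CEM cells (Homo sapiens) for inhibition, read by MTT assay, with a stated time of 2 days, tested at 10 uM (on this read-out higher numbers stand for more inhibition at the one concentration tested (going by the name of the read-out) and lower numbers for less inhibition), compound 2 gives 9%, compound 3 gives 9%, and compound 1 gives 3%. The difference between the cores of compound 3 and compound 2 is not broken down here. The change from compound 2 to compound 1 is methyl in place of hydrogen on an oxygen next to a carbonyl group, and it gave a number 6 percentage points lower from compound 2 to compound 1 (within the scatter). The change from compound 3 to compound 4 is the same one, (methyl in place of hydrogen on an oxygen next to a carbonyl group), made on the same kind of place.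

For the measured compounds named here, all three measured numbers are low, and the one measured step of this change stayed inside the usual scatter. Compound 4 is therefore expected to move by about a number 4 percentage points lower from compound 3 to compound 4 (within the scatter), because compound 1 reached only 3% after the same change. For compound 4 the estimate is 5%, with a range from -5% to 15% expected.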

Compound 4, a percentage reported as inhibition, at one concentration (the size of the read-out at that concentration, not a potency): 6%
Compound 4: middle estimate off by 1 percentage points, on the low side; low and high end bracket the measured number.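

In this assay, putting methyl in place of hydrogen on the oxygen next to the carbonyl group gives a number 3 percentage points lower from compound 3 to compound 4 (within the scatter), and set beside the earlier case, the two cores agree as far as this read-out can tell: the same change on two cores in this assay, a number 6 percentage points lower (within the scatter) from compound 2 to compound 1 and a number 3 percentage points lower (within the scatter) from compound 3 to compound 4, 3 percentage points apart, within the scatter of two such steps. Carboxy to methoxycarbonyl therefore behaves alike on these two cores, in the modest sense that neither step stands out from the ordinary spread of repeated measurements. This does not show that the change has a real effect on either core, since both steps lie within the scatter, and two cores cannot speak for a whole series.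

The compounds shown leave open what other groups would do at this place, such as an ethyl ester with its longer chain or an amide made from an amine. They also leave open whether the change would read the same way on a core whose inhibition stands well clear of the scatter, where a true difference between the free acid and its methyl ester would have room to show.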